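A few compounds are considered here, and "the series" means these few. Any claim that something is new, unique, unknown or untested is made for them only; others in the source may bear on it.

Measured so far in an ADME assay on HEK293 cells (Homo sapiens) for cytotoxicity, read by resazurin assay, with a stated time of 48 h; on this read-out higher numbers stand for lower toxicity in this test and lower numbers for higher toxicity in this test:
compound 1 `O=S(=O)(Nc1ccc(-c2nc3ccccc3o2)cc1)c1cccc(F)c1`: > 100000 nM, a limit of the assay rather than a number
compound 2 `C=Cc1ccc(S(=O)(=O)Nc2ccc3oc(-c4ccccc4)nc3c2)cc1`: 53000 nM
compound 3 `COc1ccc(S(=O)(=O)Nc2ccc3oc(-c4ccccc4)nc3c2)cc1`: 91000 nM

Compound 1 stands only at a limit, (the limit of > 100000 nM in this assay, at which 1 of the 3 values shown sits), so its place relative to the two numbers cannot be fixed further. Compound 4 `O=S(=O)(Nc1ccc(-c2nc3ccccc3o2)cc1)c1ccc(Cl)cc1` differs from it in one place: 4-chlorophenyl in place of 3-fluorophenyl on a sulfonyl sulfur. Going by the values given here, the single measured step, a 1.7-fold higher number from compound 2 to compound 3 (0.23 log units; within the scatter), is also an exchange on an aromatic carbon and stayed within the scatter. Among the compounds with values here, no measured step exchanges one halogen-bearing ring for another on a sulfonyl sulfur. The expected step of a number no higher from compound 1 to compound 4 (the limit leaves the size open) is therefore none beyond the scatter, with a fair chance that only a limit is again reported. Compound 4 is estimated at 100000 nM in this assay, between 50000 nM and 200000 nM.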

Compound 4, half-maximal cytotoxic concentration: > 100000 nM
Compound 4: no number, only a limit; the forecaster's own chance of this, stated with the estimate: 60%; the middle value sits exactly at the limit.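

Compound 1 and compound 4 each give only a limit of the assay, so the exchange of 3-fluorophenyl for 4-chlorophenyl yields no readable step: the limit of > 100000 nM in this assay, at which 2 of the 4 values shown sit.

The compounds shown leave open whether this exchange changes the read-out at all.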